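A few compounds are considered here, and "the series" means these few. Any claim that something is new, unique, unknown or untested is made for them only; others in the source may bear on it.

Measured so far in a physicochemical assay for lipophilicity, read by HPLC, measured as octanol-water partition; a lower number here means a more polar compound, a higher number a more lipophilic compound:
compound 1 (`Nc1ccccc1C(=O)N/N=C/c1ccc2no[n+]([O-])c2c1`) at 2
compound 2 (`O=C(N/N=C/c1ccc2no[n+]([O-])c2c1)c1ccccc1`) at 2.2
compound 3 (`O=C(N/N=C/c1ccc2no[n+]([O-])c2c1)c1ccccc1O`) at 1.3

Compound 2 sits at the upper end of these numbers together with compound 1, the two being level within the scatter, while compound 3 stands clearly apart from both. Compound 4 (`O=C(N/N=C/c1ccc2no[n+]([O-])c2c1)c1ccc([N+](=O)[O-])cc1`) differs from compound 2 by one change (nitro in place of hydrogen on an aromatic carbon), which is nitro in place of hydrogen on an aromatic carbon, para to a large group. Two measured steps have a hydrogen on one side (a number 0.20 log units higher from compound 1 to compound 2 (within the scatter)) and (a number 0.90 log units lower from compound 2 to compound 3 (beyond the scatter)). Neither involves nitro, so they give only a rough size and no direction. No step beyond the scatter is therefore expected in this assay for this change. The estimated step is small (a number 0.10 log units lower from compound 2 to compound 4 (within the scatter)). Compound 4 is estimated at 2.1 with an expected range (1.6 to 2.6).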

Compound 4, partition coefficient: 0.9
Compound 4: the middle estimate sits 1.20 log units above what was measured; the whole stated range lies above it.
By their numbers in this assay, from the lowest: compound 4; then compound 3; then compounds 1 and 2 (each within the scatter of the next).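

In this assay the step for nitro in place of hydrogen on an aromatic carbon, para to a large group, is a number 1.30 log units lower from compound 2 to compound 4 (beyond the scatter) and counts as large. Among these compounds, the earlier steps, among amino, hydroxy and hydrogen, reach only modest size and include no change at this place, so this is the first sign that a single change here can move the number well beyond the scatter. Nothing measured on hand accounts for the size of this step.

Still open, going by these compounds, is whether this step belongs to nitro itself or would also appear with another group at the same place, such as a nitrile, a methoxy or a carboxylic acid. Also open, on these data alone, is how nitro would behave elsewhere on this aromatic ring.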